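Piperidine-linked acetophenones as monoamine oxidase B inhibitors

A few compounds are considered here, and "the series" means these few. Any claim that something is new, unique, unknown or untested is made for them only; others in the source may bear on it.

Three compounds sharing an acetophenone core were measured in an assay on isolated protein for inhibition of Amine oxidase [flavin-containing] B (Homo sapiens), read by fluorescence, with a stated time of 30 min; on this read-out lower numbers stand for stronger inhibition and higher numbers for weaker inhibition. Compound 1 `CC(=O)c1ccc(OCCCN2CCC(c3ccccc3)CC2)cc1O` gives 19800 nM. Compound 3 `CC(=O)c1ccc(OCCCN2CCC(Cc3ccccc3)CC2)cc1O` gives 18700 nM. The difference between them is described by benzyl in place of phenyl on a saturated ring carbon and it produced a 1.1-fold lower number from compound 1 to compound 3 (0.02 log units; within the scatter). Compound 2 `CC(=O)c1ccc(OCCCCCCCCCCN2CCC(c3ccccc3)CC2)cc1O` gives 14200 nM, the lowest of the three numbers; its nearest neighbour is compound 3 and its furthest compound 1, both within the scatter of it. The difference between the core of compound 1 and the core of compound 2 is not broken down here.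

Compound 4 `CC(=O)c1ccc(OCCCCCCCCCCN2CCC(Cc3ccccc3)CC2)cc1O` has not yet been measured in this assay. Among the compounds with values here, it is related to compound 2 by benzyl in place of phenyl on a saturated ring carbon, which is the same change as the one from compound 1 to compound 3, and made at the same place. On the evidence of that one earlier step, the expected step from compound 2 to compound 4 is a 1.1-fold lower number from compound 2 to compound 4 (0.04 log units; within the scatter), set beside the measured 1.1-fold lower number from compound 1 to compound 3 (0.02 log units; within the scatter). This rests on the measured value of compound 2, 14200 nM, because the earlier step of a 1.1-fold lower number from compound 1 to compound 3 (0.02 log units; within the scatter) was within the scatter. In this assay compound 4 is therefore estimated at 13000 nM, with a likely range from 6500 nM to 26000 nM.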

Compound 4, half-maximal inhibitory concentration: 21600 nM
For compound 4 the middle estimate is 1.7-fold (0.22 log units) below the measured one; measured number inside the range.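

In this assay, benzyl in place of phenyl on a saturated ring carbon gave a 1.5-fold higher number from compound 2 to compound 4 (0.18 log units; within the scatter), and the step can be set beside the same change on the other core: the same change on two cores in this assay, a 1.1-fold lower number (0.02 log units; within the scatter) from compound 1 to compound 3 and a 1.5-fold higher number (0.18 log units; within the scatter) from compound 2 to compound 4, 1.6-fold (0.21 log units) apart, within the scatter of two such steps The change therefore carried from the core of compound 1 to the core of compound 2 with no difference between the two steps that can be told from the scatter, and neither step can itself be told from the scatter, so their opposite directions carry no weight. This does not show that the change is without effect on every core in the series, nor that these two cores respond identically, since two small steps cannot separate a slight real difference from the ordinary spread of repeated measurements.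

The compounds shown leave open how a longer chain in place of benzyl on the same saturated ring carbon would read in this assay. They also leave open whether a nitrile or a carboxylic acid on the aromatic ring of the benzyl or phenyl group would give a step that stands clear of the scatter, and whether such a step would carry from one core to the other.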